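A methoxy step from compound 2 to compound 4

The source may report more compounds than this note shows. Statements on the series, on what has been measured and on what is new or still open speak of the compounds shown alone.

In a functional assay on HCT-116 cells (Homo sapiens) for cytotoxicity, read by MTT assay (a higher number here means a weaker inhibitor, a lower number a stronger inhibitor), compound 1 (`Nc1ccccc1NC(=O)c1ccc(CSc2ncc[nH]2)cc1`) gives 5000 nM. Compound 2 (`Nc1ccccc1NC(=O)c1ccc(CSc2nc3ccccc3[nH]2)cc1`) gives 300 nM, and compound 3 (`Nc1ccccc1NC(=O)c1ccc(CSc2nnc(-c3ccccc3)o2)cc1`) gives 400 nM. These last two values lie within the scatter of each other, and both are far from the number for compound 1.

Compound 4 (`COc1ccc2nc(SCc3ccc(C(=O)Nc4ccccc4N)cc3)[nH]c2c1`) differs from compound 2 in one place: methoxy in place of hydrogen on an aromatic carbon. In words, this is methoxy in place of hydrogen on an aromatic carbon.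

Going by the values given here, only one measured step bears on this part of the structure: a 17-fold lower number from compound 1 to compound 2 (1.22 log units; beyond the scatter). That large step came with 1H-benzimidazol-2-yl in place of 1H-imidazol-2-yl on a sulfur, an exchange of the whole group on the sulfur. Among the compounds with values here, no measured compound carries a substituent on that aromatic carbon, so the data give no direction for this smaller change. The expected outcome is no step beyond the scatter, and the estimated change is a 1.2-fold higher number from compound 2 to compound 4 (0.07 log units; within the scatter). Compound 4 is expected at 350 nM, with an estimated range of 130 nM to 1000 nM.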

Compound 4, half-maximal inhibitory concentration: 200 nM
The estimate for compound 4 lay 1.8-fold (0.24 log units) above the measured number; the range from low to high includes it.
By their numbers in this assay, from the lowest: compounds 4, 2 and 3 (each within the scatter of the next); then compound 1.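

In this assay, methoxy in place of hydrogen on an aromatic carbon gives a 1.5-fold lower number from compound 2 to compound 4 (0.18 log units; within the scatter) and so does not separate the two compounds. This shows that the six-membered aromatic ring of carbon only, part of a fused system, can carry a methoxy group of 2 heavy atoms at this position without a step beyond the scatter, something that compound 2, with only hydrogen there, could not show. No available evidence bears on this result.

On these data alone, a single substituent at a single position gives no trend, so it remains open whether an amine, a carboxylic acid or a longer chain such as ethoxy on this carbon would also stay within the scatter. As far as these compounds go, it also remains open whether methoxy on the other carbons of this ring would give a similar result.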